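The source may hold more compounds than are shown below. What is called first, only, known or untested is meant among the compounds shown, and "the series" means these compounds.

Compound 1, `NC(=O)c1cccc(Cn2cc(-c3ccc4cn[nH]c4c3)ccc2=O)c1`, gives 388 nM in an assay for inhibition of MAP kinase-interacting serine/threonine-protein kinase 1 (Homo sapiens), read by luminescence and ADP-Glo, with a stated time of 2 h; a lower number here means a stronger inhibitor, a higher number a weaker inhibitor.
Compound 2, `O=c1ccc(-c2ccc3cn[nH]c3c2)cn1Cc1ccccc1`, gives 315 nM in this assay.

Going by the values given here, of these two numbers, compound 2 holds the lower one, with compound 1 as its only and nearest neighbour; the single measured step, a 1.2-fold lower number from compound 1 to compound 2 (0.09 log units; within the scatter), exchanged a carbamoyl on an aromatic carbon for hydrogen and lies within the scatter of this assay, so the two compounds cannot be ranked against each other.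

Compound 3, `O=c1ccc(-c2ccc3cn[nH]c3c2)cn1Cc1ccccc1F`, has not yet been measured. It differs from compound 2 by fluoro in place of hydrogen on an aromatic carbon. Among the compounds with values here, no measured step touches this part of the molecule: the one step known concerns the carbamoyl on the other ring and moved the number by an amount within the scatter. There is therefore nothing in the data to support a shift in either direction, and the expectation for compound 3 in this assay is a step of about a 1.1-fold lower number from compound 2 to compound 3 (0.02 log units; within the scatter), that is, no change beyond the scatter. Compound 3 is accordingly estimated at 300 nM, with a range from 120 nM to 750 nM.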

Compound 3, half-maximal inhibitory concentration: 47 nM
Compound 3: the middle estimate sits 6.4-fold (0.81 log units) above what was measured; measured number outside the range, below it.
By their numbers in this assay, from the lowest: compound 3; then compounds 2 and 1 (each within the scatter of the next).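

Changing benzyl to 2-fluorobenzyl gives a 6.7-fold lower number from compound 2 to compound 3 (0.83 log units; beyond the scatter) in this assay, so this aromatic ring is not indifferent to what it carries, which the earlier step, a 1.2-fold lower number from compound 1 to compound 2 (0.09 log units; within the scatter), with its carbamoyl on the same ring, had not revealed. The change that crosses the scatter here is small: one fluorine enters in place of a hydrogen, ortho to a large group, adding no ring, no hydrogen-bond donor or acceptor and no net charge. No measurement presented here explains the shift, so it stands as an observation about this one pair of compounds and nothing more.

As far as these compounds go, whether the lower number belongs to fluoro specifically or would also follow from chloro, methyl or methoxy ortho to a large group remains open, as does the effect of fluoro on the other carbons of this ring or of a second fluoro. Also open is whether the step would carry over to the carbamoyl-bearing ring of compound 1, since a compound holding both carbamoyl and fluoro does not stand among those shown.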